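Sulfanyl variation on the shared core: compound 3

The compounds below may be only part of what the source reports. "The series", "measured", "known", "first", "only" and "open" are said of these compounds alone.

For the measured compounds named here, compound 2 `COc1c(SCC#CCO)cnc2ccccc12` gives 23.2 ug/mL in a functional assay on P388 cells (Mus musculus) for cytotoxicity, read by MTT assay, with a stated time of 72 h (on this read-out higher numbers stand for weaker inhibition and lower numbers for stronger inhibition), the lower of the two numbers so far, with compound 1 `OCC#CCSc1cnc2ccccc2c1SCC#CCBr` at 43.2 ug/mL; the step of a 1.9-fold lower number from compound 1 to compound 2 (0.27 log units; within the scatter) is within the scatter. Compound 3 `C#CCSc1c(SCC#CCO)cnc2ccccc12` carries propargylsulfanyl in place of methoxy on an aromatic carbon. Going by the values given here, the only relevant step, from compound 1 to compound 2, exchanged groups on the same aromatic carbon without a change beyond the scatter, so no step beyond the scatter is expected in this assay here either, the estimated step being a 1.3-fold higher number from compound 2 to compound 3 (0.11 log units; within the scatter). Compound 3 is estimated at 30 ug/mL, range 12 ug/mL to 75 ug/mL.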

Compound 3, concentration for 50% inhibition: 13.3 ug/mL
Beside the measured number, compound 3's estimate is 2.3-fold (0.35 log units) above it, within the range that was stated.
By their numbers in this assay, from the lowest: compounds 3, 2 and 1 (each within the scatter of the next, the first and the last beyond it).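

In this assay the step of a 1.7-fold lower number from compound 2 to compound 3 (0.24 log units; within the scatter) stays within the scatter, so methoxy and propargylsulfanyl on this aromatic carbon cannot be told apart. Hydrogen in place of bromomethyl on a triple-bonded carbon gives a 3.2-fold lower number from compound 1 to compound 3 (0.51 log units; beyond the scatter) as the first step beyond the scatter, though a modest one, so a change on that chain registers where the exchange of groups on the aromatic carbon did not. No evidence bears on the cause of either step.

Open, going by these compounds, is whether an amine, a carboxylic acid or a longer chain on this aromatic carbon would give a step beyond the scatter.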